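Working notes: liver microsome clearance in a small sulfone series

A few compounds are considered here, and "the series" means these few. Any claim that something is new, unique, unknown or untested is made for them only; others in the source may bear on it.

Measured so far in an ADME assay on microsomes from liver (Homo sapiens) for metabolic stability, tested at 2.5 uM; a higher number here means faster removal of the compound, a lower number slower removal:
compound 1 `O=S(=O)(c1ccc(F)c(F)c1)c1cnc2c(F)cccc2c1-c1ccc(F)cc1` gives 0.78 mL/min
compound 2 `Cc1ccc(S(=O)(=O)c2cnc3cc(F)ccc3c2-c2ccc(F)cc2)cc1F` gives 2.33 mL/min
compound 3 `O=S(=O)(c1ccc(F)c(F)c1)c1cnc2c(F)cccc2c1-c1cccc(Cl)c1` gives 1.13 mL/min

Compound 2 stands highest of the three; its nearest neighbour is compound 3 and the furthest is compound 1, both gaps beyond the scatter. The cores of compound 1 and compound 2 differ, but that difference is not broken down here. From compound 1 to compound 3 the change is 3-chlorophenyl in place of 4-fluorophenyl on an aromatic carbon, and in this assay this gave a 1.4-fold higher number from compound 1 to compound 3 (0.16 log units; within the scatter).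

Pending is compound 4 `Cc1ccc(S(=O)(=O)c2cnc3cc(F)ccc3c2-c2cccc(Cl)c2)cc1F`, which differs from compound 2 by 3-chlorophenyl in place of 4-fluorophenyl on an aromatic carbon, the same change at the same place. Going by the values given here, the expectation for compound 4 in this assay is a 1.4-fold higher number from compound 2 to compound 4 (0.14 log units; within the scatter), resting on the one measured step of a 1.4-fold higher number from compound 1 to compound 3 (0.16 log units; within the scatter) applied to compound 2 at 2.33 mL/min. Compound 4 is thus estimated at 3.2 mL/min, with a range from 1.8 mL/min to 5.6 mL/min.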

Compound 4, intrinsic clearance in a liver preparation (reported as CLH), per the amount of preparation that the assay uses: 2.13 mL/min
Estimate against measurement, compound 4: 1.5-fold (0.18 log units) above; low and high end bracket the measured number.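

In this assay, 3-chlorophenyl in place of 4-fluorophenyl gives a 1.1-fold lower number from compound 2 to compound 4 (0.04 log units; within the scatter), so on the core of compound 2 the step stays within the scatter, as it does on the core of compound 1. The steps on the two cores cannot be told apart: the same change on two cores in this assay, a 1.4-fold higher number (0.16 log units; within the scatter) from compound 1 to compound 3 and a 1.1-fold lower number (0.04 log units; within the scatter) from compound 2 to compound 4, 1.6-fold (0.20 log units) apart, within the scatter of two such steps. This supports carrying the change between these two cores only as a step too small to read, and it does not show that the change would behave the same on a third core.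

Open, on these data alone, is what happens when a group other than a substituted phenyl, such as an amine or a carboxylic acid, stands on that aromatic carbon.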